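The source may hold more compounds than are shown below. What is called first, only, known or untested is meant among the compounds shown, and "the series" means these compounds.

Working notes on the series. All three compounds share one core and differ only in the group carried on the pendant phenyl. Compound 1 `CCCC[S+]([O-])c1sc2nc(-c3nccs3)cc(-c3ccc(C(C)(C)O)cc3)c2c1N` carries 1-hydroxy-1-methylethyl there; in an assay for inhibition of 15-hydroxyprostaglandin dehydrogenase [NAD(+)] (Homo sapiens), read by fluorescence, with a stated time of 15 min, in the presence of a further agent that is not named here (on this read-out higher numbers stand for weaker inhibition and lower numbers for stronger inhibition), compound 1 gives 3.6 nM. Compound 2 `CCCC[S+]([O-])c1sc2nc(-c3nccs3)cc(-c3ccc(CO)cc3)c2c1N` carries hydroxymethyl instead; in this assay compound 2 gives 2.5 nM. For the measured compounds named here, the single step between them, a 1.4-fold lower number from compound 1 to compound 2 (0.16 log units; within the scatter), is within the scatter, so compound 2 stands level with compound 1 on the two numbers so far, and neither can be called the more potent.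

Compound 3 `CCCC[S+]([O-])c1sc2nc(-c3nccs3)cc(-c3ccc(CNC(=O)NCC)cc3)c2c1N` is the next step from compound 2: (ethylcarbamoyl)amino in place of hydroxy on a saturated chain carbon bound to an aromatic carbon. Going by the values given here, only one measured step bears on this change, namely a 1.4-fold lower number from compound 1 to compound 2 (0.16 log units; within the scatter), which reshaped the group at the same position and stayed within the scatter. Among the compounds with values here, no measured step replaces hydroxy with (ethylcarbamoyl)amino, so the support is thin. On that basis the step of a 1.4-fold higher number from compound 2 to compound 3 (0.15 log units; within the scatter) is expected to remain within the scatter, with no clear direction. Compound 3 is therefore estimated at 3.5 nM, with a range from 1.2 nM to 12 nM.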

Compound 3, half-maximal inhibitory concentration: 2.1 nM
Compound 3: middle estimate off by 1.7-fold (0.22 log units), on the high side, within the range that was stated.
By their numbers in this assay, from the lowest: compounds 3, 2 and 1 (each within the scatter of the next).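

In this assay, the step of a 1.2-fold lower number from compound 2 to compound 3 (0.08 log units; within the scatter) is within the scatter, although (ethylcarbamoyl)amino, with 6 heavy atoms, takes the place of hydroxy, with 1 heavy atom, on a saturated chain carbon bound to an aromatic carbon. The wider step a 1.7-fold lower number from compound 1 to compound 3 (0.23 log units; within the scatter) is also within the scatter, so ((ethylcarbamoyl)amino)methyl stands level with both 1-hydroxy-1-methylethyl and hydroxymethyl, and among these three compounds a hydroxy group on this substituent is not needed for a number at this level. No measurement is available that would account for these three numbers standing level.

All the steps at this position lie within the scatter, so the compounds shown give neither a direction for the numbers nor a group that separates from the others. As far as these compounds go, it remains open whether an amine or a carboxylic acid on the same saturated chain carbon, or a longer chain in place of the ethyl of (ethylcarbamoyl)amino, would also stand level with compound 3 or move beyond the scatter.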